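Amide variation on a shared dichlorophenyl aminothiophene core

The source may report more compounds than this note shows. Statements on the series, on what has been measured and on what is new or still open speak of the compounds shown alone.

Measured so far:
Compound 1, `Nc1sc(-c2ccc(Cl)cc2)c(-c2ccc(Cl)cc2)c1C(=O)NC1CCC(O)CC1`, gives 5670 nM in a functional assay on PC-3 cells (Homo sapiens) for inhibition, read by sulforhodamine B assay, with a stated time of 72 h; on this read-out lower numbers stand for stronger inhibition and higher numbers for weaker inhibition.
Compound 2, `CC(C)(C)NC(=O)c1c(N)sc(-c2ccc(Cl)cc2)c1-c1ccc(Cl)cc1`, gives 15100 nM.
Compound 3, `Nc1sc(-c2ccc(Cl)cc2)c(-c2ccc(Cl)cc2)c1C(=O)N1CCC(=O)CC1=O`, gives 9230 nM.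

All three share one core and differ only in the group on the carbonyl carbon. Compound 3 stands second highest of the three numbers; its nearest neighbour is compound 1, and the step between them, a 1.6-fold higher number from compound 1 to compound 3 (0.21 log units; within the scatter), is within the scatter, as is a 1.6-fold lower number from compound 2 to compound 3 (0.21 log units; within the scatter). For the measured compounds named here, the only step read as beyond the scatter is a 2.7-fold higher number from compound 1 to compound 2 (0.43 log units; beyond the scatter), a modest one.

Compound 4, `Nc1sc(-c2ccc(Cl)cc2)c(-c2ccc(Cl)cc2)c1C(=O)N1CCCCC1=O`, is not yet measured. It differs from compound 3 in one place: 2-oxopiperidin-1-yl in place of 2,4-dioxopiperidin-1-yl on a carbonyl carbon. The two steps that bear on this position, from compound 1 to compound 3 and from compound 2 to compound 3, were both within the scatter, so the expectation for compound 4 is a step of no clear size beyond the scatter in this assay, in either direction. On that basis compound 4 is expected to come in near 9000 nM, with a plausible range from 4000 nM to 20000 nM. The estimated step, a 1.0-fold lower number from compound 3 to compound 4 (0.01 log units; within the scatter), is expected to stay within the scatter.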

Compound 4, half-maximal inhibitory concentration: 4940 nM
Beside the measured number, compound 4's estimate is 1.8-fold (0.26 log units) above it; measured number inside the range.
By their numbers in this assay, from the lowest: compounds 4, 1, 3 and 2 (each within the scatter of the next, the first and the last beyond it).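

In this assay, a 1.9-fold lower number from compound 3 to compound 4 (0.27 log units; within the scatter) leaves the reading within the scatter, so going from 2,4-dioxopiperidin-1-yl to 2-oxopiperidin-1-yl, with 7 heavy atoms and 1 hydrogen-bond acceptor against 8 and 2, gives no clear change on this carbonyl carbon. The tert-butyl compound now stands apart from a second compound, as a 3.1-fold lower number from compound 2 to compound 4 (0.49 log units; beyond the scatter) is beyond the scatter but modest, while its step to compound 3 stays within the scatter. Compound 4 also cannot be told from the hydroxylated amide, since a 1.1-fold lower number from compound 1 to compound 4 (0.06 log units; within the scatter) is within the scatter even though 2-oxopiperidin-1-yl has 0 hydrogen-bond donors, which leaves the series flat at this position apart from that modest separation.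

The compounds shown leave open whether a piperazine ring, a carboxylic acid or a longer alkyl chain on this carbonyl carbon would move the number beyond the scatter from compound 4. No data here give a reason for any of these steps.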